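Extending the acetyl to propanoyl on a shared core

The source may report more compounds than this note shows. Statements on the series, on what has been measured and on what is new or still open speak of the compounds shown alone.

Compound 1 `CCC(=O)N[C@@H]1CCCc2c1cncc2N1C(=O)c2ccc(Cl)cc2[C@@H]1C`: in an ADME assay on cells for inhibition of cytochrome P450 11B1, mitochondrial (Homo sapiens), read by HTRF (on this read-out lower numbers stand for stronger inhibition and higher numbers for weaker inhibition), compound 1 gives 414 nM.
Compound 2 `CCS(=O)(=O)N[C@@H]1CCCc2c1cncc2N1Cc2cc(Cl)ccc2C1=O`: in this assay compound 2 gives 1790 nM.
Compound 3 `CC(=O)N[C@@H]1CCCc2c1cncc2N1Cc2cc(Cl)ccc2C1=O`: in this assay compound 3 gives 2330 nM.

Among these three, compound 3 has the highest number. Its nearest neighbour is compound 2, and the step of a 1.3-fold higher number from compound 2 to compound 3 (0.11 log units; within the scatter) lies within the scatter, so the two cannot be told apart. Compound 1 is further away: compound 1 gives 414 nM against compound 3 at 2330 nM, a gap beyond the scatter, but compound 1 differs from compound 3 in more than one place.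

Compound 4 `CCC(=O)N[C@@H]1CCCc2c1cncc2N1Cc2cc(Cl)ccc2C1=O` differs from compound 3 in one place: methyl in place of hydrogen on a saturated chain carbon bound to a carbonyl carbon. Going by the values given here, only one measured step sits close to this change, a 1.3-fold higher number from compound 2 to compound 3 (0.11 log units; within the scatter), which swaps the whole group on the amine nitrogen and stays within the scatter. Among the compounds with values here, no measured pair isolates a methyl added to the acetyl; compound 1 carries propanoylamino, but its other differences prevent a clean reading. The expected step of a 1.4-fold lower number from compound 3 to compound 4 (0.14 log units; within the scatter) is therefore small, most likely within the scatter, leaning slightly lower. Compound 4 is estimated at 1700 nM, within 700 nM to 4000 nM.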

Compound 4, half-maximal inhibitory concentration: 5210 nM
Beside the measured number, compound 4's estimate is 3.1-fold (0.49 log units) below it; the measured number lies above the stated range.
By their numbers in this assay, from the lowest: compound 1; then compounds 2 and 3 (each within the scatter of the next); then compound 4.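

On the acetyl of the shared core, one added methyl is enough to move the result in this assay: a 2.2-fold higher number from compound 3 to compound 4 (0.35 log units; beyond the scatter) means weaker inhibition, so this chain carbon bound to the carbonyl carbon is not as forgiving as the earlier acetyl and ethylsulfonyl pair suggested, a pair that stayed within the scatter at a 1.3-fold higher number from compound 2 to compound 3 (0.11 log units; within the scatter). Going by these compounds alone, compound 4 also separates propanoyl from ethylsulfonyl on the amine nitrogen, with a 2.9-fold higher number from compound 2 to compound 4 (0.46 log units; beyond the scatter), and it gives the first clean reading of the methyl on the saturated ring carbon of compound 1, where losing that methyl gives a 13-fold higher number from compound 1 to compound 4 (1.10 log units; beyond the scatter), the largest of the three new steps. Nothing measured here explains why either methyl shifts the number as it does.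

From the compounds shown here alone, whether acetyl would also give a lower number than propanoyl with the ring methyl in place stays open, since only propanoyl appears alongside that methyl. Equally open, going by these compounds, is whether a longer chain such as butanoyl, or a branched one such as isobutyryl, would push the number higher still on the amine nitrogen.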